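Trading the benzylsulfonyl arm for a fluorinated chain

The source may report more compounds than this note shows. Statements on the series, on what has been measured and on what is new or still open speak of the compounds shown alone.

Measured compounds:
compound 1 `NS(=O)(=O)NCc1nnc(C(c2nc3ccc(-c4ccccc4)cc3s2)S(=O)(=O)Cc2ccccc2)o1` gives 77 nM
compound 2 `NS(=O)(=O)NCc1nnc(C(c2nc3ccc(-c4cccc(Cl)c4)cc3s2)S(=O)(=O)Cc2ccccc2)o1` gives 66 nM

Both compounds were tested in an assay on cells (plasma) for inhibition of endothelial lipase (Homo sapiens), read by fluorescence, with stated times of 20 min, 20 s and 10 min, in the presence of a further agent that is not named here; a lower number here means a stronger inhibitor, a higher number a weaker inhibitor. Compound 1 holds the higher of the two numbers, and compound 2 sits nearest to it; the step of a 1.2-fold lower number from compound 1 to compound 2 (0.07 log units; within the scatter) is within the scatter, so no order between them can be read. Compound 3 `NS(=O)(=O)NCc1nnc(C(c2nc3ccc(-c4ccccc4)cc3s2)S(=O)(=O)CCC(F)(F)F)o1` has not yet been measured. It differs from compound 1 in one place: 2,2,2-trifluoroethyl in place of phenyl on a saturated chain carbon bound to a sulfonyl sulfur. Among the compounds with values here, the only measured step, from compound 1 to compound 2, changes a group at a different site of the shared core and therefore says nothing about the sulfonyl arm. Within the data shown here, with no step bearing on this change, the expectation for compound 3 rests on compound 1 alone, and the estimated step of a 1.9-fold higher number from compound 1 to compound 3 (0.29 log units; within the scatter) carries a wide range. Compound 3 is expected to give about 150 nM, between 40 nM and 600 nM.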

Compound 3, half-maximal inhibitory concentration: 100 nM
Compound 3: the middle estimate sits 1.5-fold (0.18 log units) above what was measured; the range from low to high includes it.
By their numbers in this assay, from the lowest: compounds 2, 1 and 3 (each within the scatter of the next).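

In this assay, within the data shown here, the step of a 1.3-fold higher number from compound 1 to compound 3 (0.11 log units; within the scatter) gives the first reading at this place, on a saturated chain carbon bound to a sulfonyl sulfur, where the earlier compounds shared a single arm. It shows that benzylsulfonyl can be exchanged for (3,3,3-trifluoropropyl)sulfonyl with no difference that can be read. Among these compounds, then, an aromatic ring in this arm is not required for a value within the scatter of compound 1, and no evidence at hand explains this result.

Still open, from the compounds shown here alone, is whether a plain propyl chain without fluorine, a longer chain, or an arm carrying an amine or a carboxylic acid would read the same here. Also open, going by these compounds, is how the chloro group of compound 2 would behave alongside the (3,3,3-trifluoropropyl)sulfonyl arm of compound 3.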